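Two Fluorines in Place of Two Chlorines

A few compounds are considered here, and "the series" means these few. Any claim that something is new, unique, unknown or untested is made for them only; others in the source may bear on it.

Of the compounds shown here, three built on one shared core have been tested in a functional assay on T47D cells (Homo sapiens) for cytotoxicity, read by sulforhodamine B assay, with a stated time of 48 h, tested at 0.01 uM; a lower number here means a stronger effect, a higher number a weaker effect of the compound at the concentration tested. Compound 1 `COc1cc(-c2cc(/C=C/C(=O)c3ccc(Cl)c(Cl)c3)[nH]n2)cc(OC)c1OC` carries a 3,4-dichlorophenyl on the carbonyl carbon, and in this assay compound 1 gives 90%. Compound 2 `COc1ccc(-c2cc(/C=C/C(=O)c3ccc(N)cc3)[nH]n2)cc1OC` gives 85%, and compound 3 `COc1ccc(-c2cc(/C=C/C(=O)c3cc(OC)c(OC)c(OC)c3)[nH]n2)cc1OC` gives 91%. Going by the values given here, the number for compound 1 sits between the other two, and all three lie within the usual scatter of one another, so no compound can be called stronger or weaker than the rest; at this concentration each leaves most of the cells growing.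

Compound 4 `COc1cc(-c2cc(/C=C/C(=O)c3ccc(F)c(F)c3)[nH]n2)cc(OC)c1OC` awaits measurement. Among the compounds with values here, its only change from compound 1 is 3,4-difluorophenyl in place of 3,4-dichlorophenyl on a carbonyl carbon. Within the data shown here, no pair of measured compounds that differs in a single place is available, so the size of this step cannot be read from data. A change from one halogen-bearing ring to another is expected to move the number little, because compound 1 gives 90% and compound 3, with a quite different ring on the carbonyl carbon, gives 91%. The step from compound 1 to compound 4 is expected to be a number 2 percentage points lower from compound 1 to compound 4 (within the scatter), not beyond the scatter. Compound 4 is estimated to give 88% in this assay, with a range from 78% to 98%.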

Compound 4, a percentage reported as activity, at one concentration (the size of the read-out at that concentration, not a potency): 95%
Beside the measured number, compound 4's estimate is 7 percentage points below it; low and high end bracket the measured number.
By their numbers in this assay, from the lowest: compounds 2, 1, 3 and 4 (each within the scatter of the next).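

Going by these compounds alone, compound 1 and compound 4 form the first pair that differs in one place only, so a change on the carbonyl carbon can now be read directly. In this assay, putting 3,4-difluorophenyl in place of 3,4-dichlorophenyl gives a number 5 percentage points higher from compound 1 to compound 4 (within the scatter), which means that this exchange of one halogen pair for the other has no effect that can be told apart from the usual variation between repeat measurements at this one concentration. No measurement shown here offers a reason for this result.

Within the data shown here, the pair therefore says only that these two halogen-bearing rings cannot be separated in this test, with each compound leaving most of the cells growing, and it does not show whether any group at this position can produce a clear effect at this concentration. From the compounds shown here alone, it remains open whether a 3,4-dibromophenyl, or a phenyl ring carrying a carboxylic acid, on the carbonyl carbon of the core of compound 1 would give a number beyond the scatter, and a single concentration cannot show how these compounds would compare at higher doses.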